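A few compounds are considered here, and "the series" means these few. Any claim that something is new, unique, unknown or untested is made for them only; others in the source may bear on it.

Measured so far:

Compound 1 `N#Cc1cn(COCc2ccccc2)c2ncnc(N)c12`. In a functional assay on KB cells (Homo sapiens) for cytotoxicity (on this read-out lower numbers stand for stronger inhibition and higher numbers for weaker inhibition), compound 1 gives > 100000 nM, which is a limit of the assay rather than a number.

Compound 2 `CCOCn1cc(C#N)c2c(N)ncnc21`. In this assay compound 2 gives > 100000 nM, again a limit of the assay and not a measured number.

Among the compounds with values here, compound 1 therefore stands only at a limit, with no number of its own, and the same holds for the one other value shown, since both sit at the limit of > 100000 nM in this assay, at which 2 of the 2 values shown sit. Within the data shown here, the only measured step, from compound 1 to compound 2, is a step that the two limits leave unreadable from compound 1 to compound 2, a step that the two limits leave unreadable. It swaps methyl for phenyl on a saturated chain carbon bound to an oxygen on a saturated carbon, a part of the molecule away from where compound 3 changes.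

Compound 3 `NC(=S)c1cn(COCc2ccccc2)c2ncnc(N)c12` differs from compound 1 by a group of 3 heavy atoms (1 carbon, 1 nitrogen, 1 sulfur; no ring) in place of a group of 2 heavy atoms (1 carbon, 1 nitrogen; no ring), on an aromatic carbon. Among the measured compounds shown here, no measured step touches this place, and the one step that exists gives no size. So no direction can be read from the data; the starting point is a limit, and the change stays small in count. Compound 3 is expected to give 100000 nM, within 30000 nM to 300000 nM. The expected step of a number no higher from compound 1 to compound 3 (the limit leaves the size open) is therefore none beyond the scatter, and most likely compound 3 is expected to return a limit as well.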

Compound 3, half-maximal inhibitory concentration: > 100000 nM
Compound 3 was reported as a limit (the forecaster's own chance of this, stated with the estimate: 80%); the middle value sits exactly at the limit.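

Compound 1 and compound 3 both stand at a limit of the assay, so replacing the cyano group of compound 1 gives no step that can be read: the limit of > 100000 nM in this assay, at which 3 of the 3 values shown sit.

The compounds shown leave open how strong compound 1, compound 2 and compound 3 really are in this assay, and whether a change at either place moves the value at all.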